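A few compounds are considered here, and "the series" means these few. Any claim that something is new, unique, unknown or untested is made for them only; others in the source may bear on it.

Compound 1 `O=C(O)c1cn(Cc2ccc(-n3cccn3)cc2)c2cc(NC[C@H]3CCNC3)c(F)cc2c1=O` gives 187000 nM in an assay on isolated protein for inhibition of DNA topoisomerase 1 (Homo sapiens), with a stated time of 15 min; on this read-out lower numbers stand for stronger inhibition and higher numbers for weaker inhibition; compound 2 `O=C(O)c1cn(Cc2ccc(-c3ccccc3)cc2)c2cc(NC[C@H]3CCNC3)c(F)cc2c1=O` gives 100000 nM, and the two numbers lie within the scatter of each other. Going by the values given here, the only measured step, a 1.9-fold lower number from compound 1 to compound 2 (0.27 log units; within the scatter), concerns a different position and does not bear on the present change. Compound 3 `NC[C@@H]1CCN(c2cc3c(cc2F)c(=O)c(C(=O)O)cn3Cc2ccc(-n3cccn3)cc2)C1` differs from compound 1 by 3-(aminomethyl)pyrrolidin-1-yl in place of ((pyrrolidin-3-yl)methyl)amino on an aromatic carbon. Among the compounds with values here, no measured step covers this rearrangement of the same atoms, so the step of a 1.1-fold lower number from compound 1 to compound 3 (0.04 log units; within the scatter) is expected to stay within the scatter, with a wide range. For compound 3 the estimate in this assay is 170000 nM, with a range of 50000 nM to 600000 nM.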

Compound 3, half-maximal inhibitory concentration: 91600 nM
Beside the measured number, compound 3's estimate is 1.9-fold (0.27 log units) above it; measured number inside the range.
By their numbers in this assay, from the lowest: compounds 3, 2 and 1 (each within the scatter of the next, the first and the last beyond it).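

Going by these compounds alone, with 3-(aminomethyl)pyrrolidin-1-yl in place of ((pyrrolidin-3-yl)methyl)amino on the aromatic carbon, this assay gives a 2.0-fold lower number from compound 1 to compound 3 (0.31 log units; beyond the scatter), the first reading at this position. The number therefore responds to a rearrangement of the same atoms here, but the step is modest and lies only just beyond the scatter. No measured evidence explains this step.

From the compounds shown here alone, whether piperazin-1-yl or a longer aminoalkyl chain at this carbon would shift the number further remains open. Also open, going by these compounds, is whether the same change holds with phenyl in place of 1H-pyrazol-1-yl.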